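The compounds below may be only part of what the source reports. "The series", "measured", "known", "first", "only" and "open" are said of these compounds alone.

Measured so far:
- Compound 1, `O=C1C[C@H]2O[C@@H]3[C@@H](c4ccccc4)c4ccccc4CO[C@@H]3[C@H]2O1`: 74 nM
- Compound 2, `O=C1C[C@H]2O[C@H]([C@H](O)c3ccccc3)[C@H](O)[C@H]2O1`: 32500 nM

In a functional assay on Jurkat cells (Homo sapiens) for antiproliferative activity, read by MTT assay, with a stated time of 72 h (a lower number here means a stronger inhibitor, a higher number a weaker inhibitor), compound 1 gives 74 nM and stands as the lowest of the two numbers. Compound 2 gives 32500 nM in this assay, a much higher number, and the gap between the two lies well beyond the usual scatter. Going by the values given here, no single-point step between two measured compounds is available, so the expectation for the next compound rests on the values of compound 1 alone and on the nature of the change.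

Compound 3, `O=C1C[C@@H]2O[C@H]3[C@H](c4ccccc4)c4ccccc4CO[C@H]3[C@@H]2O1`, has not yet been measured in this assay. It differs from compound 1 as follows: the two compounds have the same atoms and bonds and differ only in configuration as drawn: 5 of 5 stereo elements differ (all stereocentres are inverted: mirror images); a stereocentre at a saturated ring carbon is drawn R in compound 1 and S in compound 3; a stereocentre at a saturated ring carbon is drawn R in compound 1 and S in compound 3; a stereocentre at a saturated ring carbon is drawn S in compound 1 and R in compound 3; a stereocentre at a saturated ring carbon is drawn S in compound 1 and R in compound 3. Compound 3 is therefore the mirror image of compound 1, with no atom added or removed. Mirror-image pairs often give different numbers in assays on living cells, and since compound 1 is the one found to be potent, the step is expected to run towards a higher number. The estimated step of an 11-fold higher number from compound 1 to compound 3 (1.03 log units; beyond the scatter) is expected to be a loss of potency beyond the scatter, though its size is uncertain. For compound 3 the expected value in this assay is 800 nM, with a range from 100 nM to 15000 nM.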

Compound 3, half-maximal inhibitory concentration: 18500 nM
For compound 3 the middle estimate is 23-fold (1.36 log units) below the measured one; measured number above the stated range.
By their numbers in this assay, from the lowest: compound 1; then compounds 3 and 2 (each within the scatter of the next).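

In this assay, going by these compounds alone, inverting the whole molecule gives a 250-fold higher number from compound 1 to compound 3 (2.40 log units; beyond the scatter), the first evidence that the handedness of this structure matters on its own, with every atom and bond left in place. Compound 3 carries the same groups as compound 1, so the potency of compound 1 cannot be credited to those groups alone; it depends on how they are arranged in space. The large loss can be attributed to configuration and to nothing else, because no other difference separates the pair: the fact that compounds 1 and 3 differ only in the configuration as drawn

All of the stereocentres change together in this step, so the compounds shown do not reveal whether one centre accounts for most of the loss or whether several contribute, and a compound with only one centre inverted would be needed to separate them. They also leave open whether the more potent mirror-image form would tolerate a new group, such as an amine or a carboxylic acid, attached to its shared core, and whether the same preference for one hand would hold in such compounds.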